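Chloro added to compound 2: a step with little guidance

This account rests on a few compounds, and the source may have more. Where it says the series, first, only, none or still open, it means among the compounds named here.

In a functional assay on PC-3 cells (Homo sapiens) for antiproliferative activity, read by MTT assay, with a stated time of 96 h (on this read-out higher numbers stand for weaker inhibition of growth and lower numbers for stronger inhibition of growth), compound 1 `Cc1ccnc(Nc2ccc3ccccc3n2)c1` gives 26700 nM and compound 2 `COc1cccc2ccc(Nc3cc(C)ccn3)nc12` gives 3820 nM while compound 3 `COc1cccc2ccc(Nc3cc(Cl)ccn3)nc12` gives 11900 nM as its value. Compound 2 holds the lowest number of the three. Compound 4 `COc1ccc(Cl)c2ccc(Nc3cc(C)ccn3)nc12` awaits measurement: chloro in place of hydrogen on an aromatic carbon, para to a methoxy group, gives the change chloro in place of hydrogen on an aromatic carbon relative to compound 2. Going by the values given here, two measured steps bear on it only loosely: methoxy in place of hydrogen gave a 7.0-fold lower number from compound 1 to compound 2 (0.84 log units; beyond the scatter) and chloro in place of methyl gave a 3.1-fold higher number from compound 2 to compound 3 (0.49 log units; beyond the scatter) as the second. From the compounds shown here alone, neither places chloro on this carbon, so in this assay no step beyond the scatter is expected, and the direction stays open. The estimated step is a 1.1-fold lower number from compound 2 to compound 4 (0.04 log units; within the scatter) for now. Compound 4 is expected near 3500 nM within a range from 1000 nM to 12000 nM on this read-out.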

Compound 4, concentration for 50% growth inhibition: > 30000 nM
Compound 4: only a limit was reported (the forecaster's own chance of this, stated with the estimate: 5%); at least 8.5-fold (0.93 log units) between middle value and limit.
By their numbers in this assay, from the lowest: compound 2; then compound 3; then compound 1. At a limit, above all of these: compound 4.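

Chloro in place of hydrogen on this aromatic carbon, para to a methoxy group, gives an at least 7.8-fold higher number from compound 2 to compound 4 (0.89 log units; beyond the scatter) in this assay, so this carbon of the core does not tolerate every change. The earlier compounds shown here carried no substituent here and could not show this. Compound 4 is reported only as a limit, so the true size of the step stays unknown: the limit of > 30000 nM in this assay, at which 1 of the 4 values shown sits.

From the compounds shown here alone, what an amine or a hydroxyl group on this carbon would give remains open. Whether the rise belongs to chloro itself or to any group at this place cannot be told.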